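The compounds below may be only part of what the source reports. "The series", "measured", "known", "first", "only" and "open" are said of these compounds alone.

Compound 1, `CCOC(=O)c1oc2ccc(NS(=O)(=O)c3cccc(C)c3)cc2c1C`: 101000 nM in a functional assay on MCF7 cells (Homo sapiens) for antiproliferative activity, read by MTT assay, with a stated time of 72 h; on this read-out lower numbers stand for stronger inhibition and higher numbers for weaker inhibition
Compound 2, `CCOC(=O)c1oc2ccc(NS(=O)(=O)c3ccccc3Cl)cc2c1C`: > 200000 nM in this assay

Compound 2 gives no number in this assay but only the limit (the limit of > 200000 nM in this assay, at which 1 of the 2 values shown sits). The one measured step on the sulfonyl sulfur is an at least 1.9-fold higher number from compound 1 to compound 2 (0.29 log units; that floor lies within the scatter), and its floor lies within the scatter, so the swap of aryl groups at that position has not shown a change that can be trusted. Compound 3, `CCOC(=O)c1oc2ccc(NS(=O)(=O)c3ccc([N+](=O)[O-])cc3)cc2c1C`, differs from compound 2 only at the same sulfonyl sulfur: 4-nitrophenyl in place of 2-chlorophenyl on a sulfonyl sulfur. Nothing measured bears on the 4-nitrophenyl group itself, so the step from compound 2 to compound 3 is expected to stay within the scatter, with a fair chance that compound 3 again returns only a limit. Compound 3 is therefore estimated at 150000 nM, with a range from 60000 nM to 400000 nM, which means an expected step of an at least 1.3-fold lower number from compound 2 to compound 3 (0.12 log units; that floor lies within the scatter).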

Compound 3, half-maximal inhibitory concentration: 69600 nM
For compound 3 the middle estimate is 2.2-fold (0.33 log units) above the measured one, within the range that was stated.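

The sulfonyl sulfur now shows its first change that can be trusted: in this assay, 4-nitrophenyl in place of 2-chlorophenyl gives an at least 2.8-fold lower number from compound 2 to compound 3 (0.45 log units; beyond the scatter). Going by these compounds, the true size of that step stays unknown, as compound 2 gives a limit and not a number: the limit of > 200000 nM in this assay, at which 1 of the 3 values shown sits. Set against 3-methylphenyl, the same 4-nitrophenyl group gives a 1.5-fold lower number from compound 1 to compound 3 (0.16 log units; within the scatter), so these two aryl groups cannot be told apart at this position, and the one change that can be trusted separates only 2-chlorophenyl from 4-nitrophenyl.

The compounds shown leave open whether a group other than a substituted phenyl, such as a short alkyl chain, can take the place of the aryl group on the sulfonyl sulfur. They also leave open what an amine or a carboxylic acid would do in place of the nitro group.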